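This account rests on a few compounds, and the source may have more. Where it says the series, first, only, none or still open, it means among the compounds named here.

Compound 1 `COc1ccc2c(=O)c(/C=C/C(=O)Nc3ccc(Cl)cc3)coc2c1` is the starting point of this comparison. Within the data shown here, in a functional assay on Huh-7 cells (Homo sapiens) for inhibition, read by MTT assay, with a stated time of 48 h (on this read-out higher numbers stand for weaker inhibition and lower numbers for stronger inhibition), compound 1 gives 37100 nM, the highest of the three numbers measured so far. Compound 2 `Cc1ccccc1NC(=O)/C=C/c1coc2cc(O)ccc2c1=O` gives 11100 nM in this assay, and compound 3 `O=C(/C=C/c1coc2cc(O)ccc2c1=O)Nc1ccccc1` gives 3880 nM, so compound 1 stands at the weak end, beyond the scatter from both. Among the measured compounds shown here, the one single-point step measured so far is a 2.9-fold lower number from compound 2 to compound 3 (0.46 log units; beyond the scatter), a change on the aryl amide side of the shared core.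

Compound 4 `COc1ccc(NC(=O)/C=C/c2coc3cc(OC)ccc3c2=O)cc1` differs from compound 1 in one place: methoxy in place of chloro on an aromatic carbon. For the measured compounds named here, no measured step covers this particular swap; the step from compound 2 to compound 3 concerns a different group at a different ring position, so it offers only the general hint that changes on that aromatic ring move the number modestly.

With nothing directly comparable, compound 4 is expected to stay close to compound 1, with an estimated step of a 1.2-fold lower number from compound 1 to compound 4 (0.09 log units; within the scatter). The expected value for compound 4 in this assay is therefore 30000 nM, estimated to fall between 9000 nM and 100000 nM.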

Compound 4, half-maximal inhibitory concentration: > 100000 nM
Compound 4 ended at the assay's limit; the forecaster's own chance of this, stated with the estimate: 15%; middle value at least 3.3-fold (0.52 log units) from the limit.
By their numbers in this assay, from the lowest: compound 3; then compound 2; then compound 1. At a limit, above all of these: compound 4.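

In this assay, the change from 4-chlorophenyl to 4-methoxyphenyl gives an at least 2.6-fold higher number from compound 1 to compound 4 (0.43 log units; beyond the scatter), with the rest of the molecule unchanged. Among these compounds, the value for compound 4 is a limit of the assay and not a number: the limit of > 100000 nM in this assay, at which 1 of the 4 values shown sits. The earlier compounds held no change at this place, and this pair shows that the group on this aromatic carbon alone can shift the read-out towards weaker inhibition, although only the direction and the minimum size of the step can be read.

Going by these compounds, what remains open is whether an amine, a carboxylic acid or plain hydrogen at this place would stay near compound 1 at 37100 nM or move further from it. On these data alone, it is also open whether the same swap would act in the same direction on the hydroxy-bearing core of compound 3.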